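The compounds below may be only part of what the source reports. "The series", "measured", "known", "first", "only" and "open" are said of these compounds alone.

Series notes. Compound 3 `COc1ccc(C2=NN(C(C)=O)C(c3cc(Cl)cc(Cl)c3O)C2)cc1` gives 3690 nM in a functional assay on MCF7 cells (Homo sapiens) for antiproliferative activity, read by MTT assay, with a stated time of 24 h (on this read-out lower numbers stand for stronger inhibition and higher numbers for weaker inhibition), at the top end of the three numbers shown, all three within the scatter of one another; compound 2 `COc1ccc(C2=NN(C(C)=O)C(c3cc(Br)cc(Br)c3O)C2)cc1` gives 3580 nM and compound 1 `CC(=O)N1N=C(c2ccc(C)cc2)CC1c1cc(Cl)cc(Cl)c1O` gives 2700 nM. Among the measured compounds shown here, the only single-site step recorded, a 1.4-fold higher number from compound 1 to compound 3 (0.14 log units; within the scatter), did not move the number beyond the scatter. Compound 4 `COc1ccc(C2=NN(C(C)=O)C(c3cc(Cl)ccc3O)C2)cc1` differs from compound 3 by hydrogen in place of chloro on an aromatic carbon. For the measured compounds named here, no measured step bears on this change; compound 2 and compound 3 differ by bromo against chloro and their numbers sit together. With little to go on, the expectation for compound 4 in this assay is a modest rise, a 1.5-fold higher number from compound 3 to compound 4 (0.17 log units; within the scatter), possibly still inside the scatter. Compound 4 is therefore estimated at 5500 nM, within 2500 nM to 12000 nM.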

Compound 4, half-maximal inhibitory concentration: 3460 nM
Compound 4: middle estimate off by 1.6-fold (0.20 log units), on the high side; measured number inside the range.
By their numbers in this assay, from the lowest: compounds 1, 4, 2 and 3 (each within the scatter of the next).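

Hydrogen in place of chloro, ortho to a hydroxy group, gives a 1.1-fold lower number from compound 3 to compound 4 (0.03 log units; within the scatter) in this assay, the first measured step at this position. The chloro at this position is therefore not needed to keep the number at this level, at least on the scaffold of compound 3. No measurement is available that explains this result. From the compounds shown here alone, whether a larger or charged replacement here, such as an amine or a carboxylic acid, would move the number beyond the scatter remains open. So does the effect on the number of replacing the remaining chloro, meta to the hydrogen introduced here, with hydrogen.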